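The compounds below may be only part of what the source reports. "The series", "measured", "known", "first", "only" and "open" are said of these compounds alone.

Measured so far in an ADME assay on HeLa Rh cells (Homo sapiens) for cytotoxicity, read by microscopy; a lower number here means that less compound is tolerated, a higher number that more compound is tolerated:
compound 1 `COc1cc(CC(O)c2ccc(-c3ccc(Cl)cc3)cc2)c([N+](=O)[O-])cc1OC`, 4100 nM
compound 2 `COc1cc(CC(O)c2ccc(-c3cccc(Cl)c3)cc2)c([N+](=O)[O-])cc1OC`, 5900 nM
compound 3 `COc1cc(CC(O)c2ccc(-c3cccc(F)c3)cc2)c([N+](=O)[O-])cc1OC`, 7400 nM

Compound 3 sits at the upper end of the three numbers in this assay, but nothing separates it from the others: the steps of a 1.8-fold higher number from compound 1 to compound 3 (0.26 log units; within the scatter) and a 1.3-fold higher number from compound 2 to compound 3 (0.10 log units; within the scatter) are both inside the scatter, as is a 1.4-fold higher number from compound 1 to compound 2 (0.16 log units; within the scatter). Across the three compounds the halogen and its place on the outer ring have not moved the number.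

Compound 4 `COc1cc(CC(O)c2ccc(-c3cccc([N+](=O)[O-])c3)cc2)c([N+](=O)[O-])cc1OC` differs from compound 3 by nitro in place of fluoro on an aromatic carbon. Among the compounds with values here, the only measured step that exchanges one group for another at this position is the fluoro-for-chloro step, which stayed within the scatter; the two steps that move a group around the ring did the same. None of these touches a nitro group, so the bearing is indirect. With every measured step flat, no step beyond the scatter is expected for compound 4 in this assay, and the expected step from compound 3 is a 1.1-fold lower number from compound 3 to compound 4 (0.02 log units; within the scatter). For compound 4 the estimate is 7000 nM, with a range from 3000 nM to 16000 nM.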

Compound 4, half-maximal cytotoxic concentration: 5500 nM
Beside the measured number, compound 4's estimate is 1.3-fold (0.10 log units) above it; measured number inside the range.
By their numbers in this assay, from the lowest: compounds 1, 4, 2 and 3 (each within the scatter of the next).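

In this assay, nitro at this place on the outer ring, which unlike fluoro brings hydrogen-bond acceptors and more heavy atoms, gives steps no larger than those among the halogens: a 1.3-fold lower number from compound 3 to compound 4 (0.13 log units; within the scatter) and a 1.1-fold lower number from compound 2 to compound 4 (0.03 log units; within the scatter) and a 1.3-fold higher number from compound 1 to compound 4 (0.13 log units; within the scatter) all stay within the scatter. The flat reading at this position, so far resting on chloro and fluoro alone, therefore now extends to a group of a different kind, though the claim holds only for these four compounds. Nothing on hand explains this flatness.

As far as these compounds go, it remains open whether an amine, a carboxylic acid or a longer chain on this aromatic carbon would stay as flat as nitro. From the compounds shown here alone, whether changes elsewhere on the shared core would move the number also remains open.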